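The compounds below may be only part of what the source reports. "The series", "measured", "known", "first", "only" and "open" are said of these compounds alone.

Two compounds share one core and differ only in the group carried on a nitrogen on an aromatic ring. Compound 1 `COc1ccc(Nc2cc(C)nc(SCc3nc4ccccc4[nH]3)n2)cc1` carries a 4-methoxyphenyl there, and in a functional assay on MGC-803 cells (Homo sapiens) for cytotoxicity, read by MTT assay, with a stated time of 72 h (a higher number here means a weaker inhibitor, a lower number a stronger inhibitor), compound 1 gives 51100 nM. Compound 2 `Cc1cc(NC(C)C)nc(SCc2nc3ccccc3[nH]2)n1` carries an isopropyl in that place. In this assay compound 2 reaches only a limit of the assay, > 100000 nM. The measured step of an at least 1.9-fold higher number from compound 1 to compound 2 (0.29 log units; that floor lies within the scatter) is thus only a floor, and its true size cannot be fixed because of the limit of > 100000 nM in this assay, at which 1 of the 2 values shown sits. Compound 3 `Cc1cc(Nc2ccc(Cl)cc2)nc(SCc2nc3ccccc3[nH]2)n1` takes the next step: 4-chlorophenyl in place of isopropyl on a nitrogen on an aromatic ring. For the measured compounds named here, in kind this change runs opposite to the measured step, an aromatic group returning in place of the isopropyl, and the one guide is that compound 1, which carries an aromatic group in this place, gives 51100 nM. The step expected is an at least 2.5-fold lower number from compound 2 to compound 3 (0.39 log units; beyond the scatter), back toward a number the assay can report. For compound 3 in this assay the expected value is 40000 nM, with a range from 15000 nM to 100000 nM.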

Compound 3, half-maximal inhibitory concentration: 28200 nM
For compound 3 the middle estimate is 1.4-fold (0.15 log units) above the measured one; measured number inside the range.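

In this assay, for the compounds shown here, 4-chlorophenyl in place of isopropyl on the nitrogen gives an at least 3.5-fold lower number from compound 2 to compound 3 (0.54 log units; beyond the scatter), the first step at this position that clears the usual scatter, whereas the earlier floor did not. The aromatic group therefore separates from the isopropyl in this small set: compound 1 and compound 3 both give numbers the assay can report, while compound 2 does not, and none of the three goes against this. The full size of the step stays unknown, and exchanging one substituent on the aromatic ring for another barely registers, with chloro in place of methoxy on an aromatic carbon giving a 1.8-fold lower number from compound 1 to compound 3 (0.26 log units; within the scatter), but the first point holds only as a floor because compound 2 sits at a limit of the assay: the limit of > 100000 nM in this assay, at which 1 of the 3 values shown sits.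

These compounds leave open whether an aromatic ring is needed at all, since a cyclohexyl ring or a longer chain on the same nitrogen would separate ring from chain and aromatic from non-aromatic. They also leave open whether an amine or a carboxylic acid on the aromatic ring could move the number much further from that of compound 3, at 28200 nM.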